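The source may hold more compounds than are shown below. What is called first, only, known or untested is meant among the compounds shown, and "the series" means these compounds.

Measured compounds:
compound 1 `CCC1=C(O)c2c(oc(-c3ccc(Br)cc3)cc2=O)C(CC)(CC)C1=O`: 15.7 uM
compound 2 `CCC1=C(O)c2c(oc(-c3cccc(C(F)(F)F)c3)cc2=O)C(CC)(CC)C1=O`: 5.42 uM
compound 3 `CCC1=C(O)c2c(oc(-c3ccccc3C(F)(F)F)cc2=O)C(CC)(CC)C1=O`: 43.1 uM

The series was tested in a functional assay on KBVIN cells (Homo sapiens) for antiproliferative activity, read by sulforhodamine B assay, with a stated time of 3 days; on this read-out lower numbers stand for an effect already at smaller amounts and higher numbers for an effect only at larger amounts of compound. Compound 1 stands second highest of the three numbers. Its nearest neighbour is compound 3, whose value in this assay is higher by an amount beyond the usual scatter, and the furthest is compound 2, whose value is lower, again beyond the scatter. All three compounds share one core and differ only in the aryl group attached to it.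

Compound 4 `CCC1=C(O)c2c(oc(-c3ccc(OC)cc3C)cc2=O)C(CC)(CC)C1=O` has not yet been measured. Relative to compound 1 the change is 4-methoxy-2-methylphenyl in place of 4-bromophenyl on an aromatic carbon. Nothing in the measured set isolates a single change of this kind, so the expectation rests on the spread of the three values. The account expects a small step from compound 1 to compound 4, upward rather than downward, likely within or just beyond the scatter, partly because compound 3 gives 43.1 uM with a differently substituted aryl group, and compound 2 gives 5.42 uM. The expected step is a 1.3-fold higher number from compound 1 to compound 4 (0.11 log units; within the scatter). Compound 4 is estimated at 20 uM, with a range from 8 uM to 50 uM.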

Compound 4, concentration for half-maximal effect: 2.62 uM
Beside the measured number, compound 4's estimate is 7.6-fold (0.88 log units) above it; the whole stated range lies above it.
By their numbers in this assay, from the lowest: compound 4; then compound 2; then compound 1; then compound 3.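

In this assay, replacing 4-bromophenyl with 4-methoxy-2-methylphenyl on the aromatic carbon next to the ring oxygen gives a 6.0-fold lower number from compound 1 to compound 4 (0.78 log units; beyond the scatter), so this position of the shared core responds strongly to the make-up of the aryl group, not only to the two halogen-bearing patterns or the trifluoromethyl groups seen earlier. The change removes the bromine and brings in a methoxy group and a methyl group at once, so the step cannot be divided among them. Nothing available explains why the number falls.

The compounds shown leave open how 4-methoxyphenyl or 2-methylphenyl alone would read in this assay. They also leave open whether an amine or a carboxylic acid on this aryl ring would keep the effect.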